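Straight Propyl Chain in Place of a Branched Isopropyl

The compounds below may be only part of what the source reports. "The series", "measured", "known", "first", "only" and "open" are said of these compounds alone.

Compound 2 `CC(C)C1CCC(N(Cc2ccc(C(=O)NCCC(=O)O)cc2)C(=O)Nc2ccc(OC(F)(F)F)cc2)CC1` is the anchor of this small set. Among the compounds with values here, in an in vitro assay on BHK cells for inhibition of Glucagon receptor (Homo sapiens) (a higher number here means a weaker inhibitor, a lower number a stronger inhibitor), compound 2 gives 59 nM, the only true number among the values shown. Compound 1 `O=C(O)CCNC(=O)c1ccc(CN(C(=O)Nc2ccc(OC(F)(F)F)cc2)C2CCC(C(=O)NCC3CC3)CC2)cc1` reaches only a limit of the assay: in this assay compound 1 gives > 10000 nM. Within the data shown here, the single measured step, an at least 160-fold lower number from compound 1 to compound 2 (2.22 log units; beyond the scatter), exchanged a (cyclopropylmethyl)carbamoyl group for isopropyl on a saturated ring carbon, and because one end rests at the limit of > 10000 nM in this assay, at which 1 of the 2 values shown sits, its full size is unknown.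

Compound 3 `CCCC1CCC(N(Cc2ccc(C(=O)NCCC(=O)O)cc2)C(=O)Nc2ccc(OC(F)(F)F)cc2)CC1` differs from compound 2 by propyl in place of isopropyl on a saturated ring carbon. The measured step concerns a different, much larger exchange and gives no direct guide here, so only a small shift is anticipated. Compound 3 is expected to give about 80 nM in this assay, plausibly between 25 nM and 300 nM. The expected step of a 1.4-fold higher number from compound 2 to compound 3 (0.13 log units; within the scatter) is judged to lie within the usual scatter.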

Compound 3, half-maximal inhibitory concentration: 122 nM
Compound 3: the middle estimate sits 1.5-fold (0.18 log units) below what was measured, within the range that was stated.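

Two groups with the same atoms, joined differently, are enough to shift the result at this position: propyl in place of isopropyl gives a 2.1-fold higher number from compound 2 to compound 3 (0.32 log units; beyond the scatter), a modest step. Propyl in place of the (cyclopropylmethyl)carbamoyl group gives an at least 81-fold lower number from compound 1 to compound 3 (1.91 log units; beyond the scatter), so the large difference from that group holds for the straight chain as well as for the branched one. The full size of this step stays unknown because compound 1 rests at a limit of the assay: the limit of > 10000 nM in this assay, at which 1 of the 3 values shown sits.

Still open, from the compounds shown here alone, is how a shorter ethyl group, a longer butyl chain or a cyclopropyl ring would behave on this ring carbon. The compounds shown also cannot say whether a small group carrying a hydroxyl or an amine would be tolerated there, or which part of the (cyclopropylmethyl)carbamoyl group accounts for its large step.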